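The compounds below may be only part of what the source reports. "The series", "measured", "known", "first", "only" and "open" are said of these compounds alone.

Compound 1, `O=c1[nH]cnn2c([C@@H]3O[C@H](CO)C[C@H]3O)ccc12`, and compound 2, `O=c1[nH]cnn2c([C@@H]3O[C@H](CO)[C@@H](O)[C@H]3O)ccc12`, share one core, while compound 3, `Nc1ncnn2c([C@@H]3O[C@H](CO)C[C@H]3O)cc(-c3ccc(Cl)cc3)c12`, carries another; the difference between the two cores is not broken down here. In an ADME assay on cells (Macrophage, Mus musculus) for cytotoxicity (on this read-out lower numbers stand for higher toxicity in this test and higher numbers for lower toxicity in this test), compound 1 gives > 64000 nM, which is a limit of the assay and not a number. Compound 2 likewise gives > 64000 nM, again a limit. The change hydroxy in place of hydrogen on a saturated ring carbon therefore gives a step, a step that the two limits leave unreadable from compound 1 to compound 2, that the two limits leave unreadable. Going by the values given here, compound 3 gives 24000 nM, the only number among the three, alongside (the limit of > 64000 nM in this assay, at which 2 of the 3 values shown sit). Compound 4, `Nc1ncnn2c([C@@H]3O[C@H](CO)[C@@H](O)[C@H]3O)cc(-c3ccc(Cl)cc3)c12`, applies the same change, (hydroxy in place of hydrogen on a saturated ring carbon), to compound 3. Since the earlier step from compound 1 to compound 2 is not readable, the step from compound 3 to compound 4, a 1.3-fold higher number from compound 3 to compound 4 (0.12 log units; within the scatter), is expected to be small. Compound 4 is accordingly estimated at 32000 nM, between 12000 nM and 80000 nM.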

Compound 4, half-maximal cytotoxic concentration: 5000 nM
For compound 4 the middle estimate is 6.4-fold (0.81 log units) above the measured one, and the stated range ends above it.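

In this assay, hydroxy in place of hydrogen on a saturated ring carbon gives a 4.8-fold lower number from compound 3 to compound 4 (0.68 log units; beyond the scatter), a modest step beyond the scatter. On the core of compound 1 the same change cannot be read, since compound 1 and compound 2 both stand at a limit of the assay and not at a number: the limit of > 64000 nM in this assay, at which 2 of the 4 values shown sit. The step is therefore seen on one core only, and it shows neither that the change carries over between the cores nor that its effect depends on the core.

The compounds shown leave open whether the step is specific to the hydroxy. An amine or a methoxy group at the same place might give a step of similar size or a different one.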